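The source may hold more compounds than are shown below. What is called first, only, known or untested is meant among the compounds shown, and "the series" means these compounds.

Three members of this series have numbers in a functional assay on A549 cells (Homo sapiens) for cytotoxicity, read by MTT assay, with a stated time of 72 h; a higher number here means a weaker inhibitor, a lower number a stronger inhibitor. Compound 1 `COc1cc(Nc2nc3ccccc3nc2S(=O)(=O)c2ccc(C)cc2)cc(OC)c1` gives 8060 nM. Compound 2 `Cc1ccc(S(=O)(=O)c2nc3ccccc3nc2Nc2cccc(O)c2)cc1` gives 6080 nM, and compound 3 `Cc1ccc(S(=O)(=O)c2nc3ccccc3nc2Nc2ccc(Cl)cc2)cc1` gives 54200 nM. Compound 1 therefore stands second highest of the three: the step of a 1.3-fold lower number from compound 1 to compound 2 (0.12 log units; within the scatter) lies within the scatter, whereas a 6.7-fold higher number from compound 1 to compound 3 (0.83 log units; beyond the scatter) and an 8.9-fold higher number from compound 2 to compound 3 (0.95 log units; beyond the scatter) lie beyond it. All three measured steps exchange the aryl group on the nitrogen on the aromatic ring; none of them alters the (4-methylphenyl)sulfonyl group.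

Compound 4 `COc1cc(Nc2nc3ccccc3nc2S(=O)(=O)c2ccc(F)cc2)cc(OC)c1` differs from compound 1 by fluoro in place of methyl on an aromatic carbon. Among the compounds with values here, no measured step bears on this part of the molecule, so the change in this assay is not anchored by any number at hand. With nothing to point either way, the working expectation is no step beyond the scatter. Compound 4 is thus expected to give 8000 nM in this assay, with a range from 3000 nM to 22000 nM. The expected step is a 1.0-fold lower number from compound 1 to compound 4 (0.00 log units; within the scatter).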

Compound 4, half-maximal inhibitory concentration: 5450 nM
Beside the measured number, compound 4's estimate is 1.5-fold (0.17 log units) above it; measured number inside the range.
By their numbers in this assay, from the lowest: compounds 4, 2 and 1 (each within the scatter of the next); then compound 3.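

The (4-methylphenyl)sulfonyl group now has its first measured change: in this assay, fluoro in place of methyl on an aromatic carbon, para to a large group, gives a 1.5-fold lower number from compound 1 to compound 4 (0.17 log units; within the scatter). With the 3,5-dimethoxyphenyl group kept on the nitrogen, this single pair shows no step beyond the scatter at this position, whereas exchange of the aryl group on the nitrogen gives a 6.7-fold higher number from compound 1 to compound 3 (0.83 log units; beyond the scatter). No supporting data bear on this result.

Open, as far as these compounds go, is whether an amine, a carboxylic acid or a longer chain on the same aromatic carbon would also stay within the scatter. Also open, from the compounds shown here alone, is whether fluoro in place of methyl would give a similar step with the 3-hydroxyphenyl group of compound 2 or the 4-chlorophenyl group of compound 3 on the nitrogen.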